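This account rests on a few compounds, and the source may have more. Where it says the series, first, only, none or still open, it means among the compounds named here.

Measured so far in an assay on isolated protein for binding affinity to Equilibrative nucleoside transporter 1 (Homo sapiens); a lower number here means a stronger inhibitor, a higher number a weaker inhibitor:
compound 1, `OC[C@H]1O[C@@H](n2cnc3c(NCc4ccco4)ncnc32)[C@H](O)[C@@H]1O`, gives 36300 nM
compound 2, `Cc1ccc(CSc2ncnc3c2ncn3[C@@H]2O[C@H](CO)[C@@H](O)[C@H]2O)cc1`, gives 457 nM
compound 3, `OC[C@H]1O[C@@H](n2cnc3c(CSc4cccc(Br)c4)ncnc32)[C@H](O)[C@@H]1O`, gives 363 nM

Compound 3 holds the lowest of the three numbers in this assay, though its gap to compound 2, a 1.3-fold lower number from compound 2 to compound 3 (0.10 log units; within the scatter), does not separate the two. Its gap to compound 1 is large, a 100-fold lower number from compound 1 to compound 3 (2.00 log units; beyond the scatter), as is the parallel step a 79-fold lower number from compound 1 to compound 2 (1.90 log units; beyond the scatter). Both large steps concern the exchange of the whole side chain on the aromatic carbon of the shared core, not a change within an aryl ring.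

Compound 4, `OC[C@H]1O[C@@H](n2cnc3c(CSc4ccc(F)cc4)ncnc32)[C@H](O)[C@@H]1O`, is not yet measured. It differs from compound 3 by 4-fluorophenyl in place of 3-bromophenyl on a sulfur. Among the measured compounds shown here, no measured step alters only the substituent on a phenyl ring; the nearest comparison is a 1.3-fold lower number from compound 2 to compound 3 (0.10 log units; within the scatter), in which a different arrangement around the sulfur and a different ring substituent together gave no change beyond the scatter. On that basis no step beyond the scatter is expected from compound 3 to compound 4, and the expected step is a 1.1-fold higher number from compound 3 to compound 4 (0.04 log units; within the scatter). For compound 4 the estimated value in this assay is 400 nM, with an expected range from 150 nM to 1200 nM.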

Compound 4, half-maximal inhibitory concentration: 158 nM
Beside the measured number, compound 4's estimate is 2.5-fold (0.40 log units) above it; measured number inside the range.
By their numbers in this assay, from the lowest: compound 4; then compounds 3 and 2 (each within the scatter of the next); then compound 1.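

In this assay, among the compounds shown here, 4-fluorophenyl in place of 3-bromophenyl, on a sulfur whose other neighbour is a saturated chain carbon, gives a 2.3-fold lower number from compound 3 to compound 4 (0.36 log units; beyond the scatter) and is the only measured step that alters the aryl group alone, showing that the series responds to this group even with the rest of the side chain held fixed. For the compounds shown here, the change also gives compound 4 a separation that compound 3 lacks from compound 2, with a 2.9-fold lower number from compound 2 to compound 4 (0.46 log units; beyond the scatter) in place of a gap within the scatter, and it extends the large side-chain step to a 230-fold lower number from compound 1 to compound 4 (2.36 log units; beyond the scatter) while leaving compound 4 with the lowest number of the series so far. Nothing measured here accounts for the gain.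

Going by these compounds, the step changes the halogen and its ring position together, so the contribution of each remains unresolved, and it is open whether 4-bromophenyl or 3-fluorophenyl on the same sulfur would read like compound 3 or like compound 4. Also open, on these data alone, is how a phenyl ring carrying an amine or a carboxylic acid would read in this assay when placed on this sulfur.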